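The source may report more compounds than this note shows. Statements on the series, on what has been measured and on what is new or still open speak of the compounds shown alone.

Compound 1 `COc1ccc(-c2cc(C(=O)Nc3nc4ccc(Cl)cc4s3)nc3cc(-c4ccccc4)nn23)cc1` gives 5880 nM in a functional assay on HeLa cells (Homo sapiens) for cytotoxicity, read by MTT assay, with a stated time of 48 h; a lower number here means a stronger inhibitor, a higher number a weaker inhibitor. Compound 2 `COc1ccc(-c2cc(C(=O)Nc3nc4ccc(Cl)cc4s3)nc3cc(-c4ccccc4)nn23)cc1OC` gives 9120 nM in this assay. Compound 3 `COc1cc(-c2cc(C(=O)Nc3nc4ccc(Cl)cc4s3)nc3cc(-c4ccccc4)nn23)cc(OC)c1OC` gives 22400 nM in this assay.

Among these three, compound 3 carries the highest number, which means the weakest inhibition; the change from compound 1 to compound 3 was a 3.8-fold higher number from compound 1 to compound 3 (0.58 log units; beyond the scatter) and from compound 2 to compound 3 was a 2.5-fold higher number from compound 2 to compound 3 (0.39 log units; beyond the scatter), both beyond the scatter, while a 1.6-fold higher number from compound 1 to compound 2 (0.19 log units; within the scatter) stayed within it. Compound 4 `COc1ccc2nc(NC(=O)c3cc(-c4cc(OC)c(OC)c(OC)c4)n4nc(-c5ccccc5)cc4n3)sc2c1` differs from compound 3 in one place: methoxy in place of chloro on an aromatic carbon. Among the measured compounds shown here, none of the measured steps touches this part of the shared core; all three concern methoxy groups on the other aromatic ring, so they give no direct guide to how a swap at the 6-chloro-1,3-benzothiazol-2-yl group will read. Without such a guide, the most defensible expectation is a step near zero, within the scatter, in either direction: the estimated step is a 1.1-fold higher number from compound 3 to compound 4 (0.03 log units; within the scatter). Compound 4 is therefore expected to give about 24000 nM, within a range from 8000 nM to 75000 nM.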

Compound 4, half-maximal inhibitory concentration: 8700 nM
Estimate against measurement, compound 4: 2.8-fold (0.44 log units) above, and the stated range covers the measured number.
By their numbers in this assay, from the lowest: compounds 1, 4 and 2 (each within the scatter of the next); then compound 3.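

Among the compounds shown here, the earlier steps all changed methoxy groups on the other aromatic ring, so this is the first view of the 6-chloro-1,3-benzothiazol-2-yl group. In this assay, moving to the 6-methoxy-1,3-benzothiazol-2-yl group gives a 2.6-fold lower number from compound 3 to compound 4 (0.41 log units; beyond the scatter), which shows that this position is not silent: a modest move towards stronger inhibition lies beyond the scatter. Nothing at hand explains why the number falls.

For the compounds shown here, this step rests on a single pair, so it remains open whether the same swap would read alike in compound 1, with its single methoxy group on the other ring. Also open, from the compounds shown here alone, is how a fluoro group, an amine or a carboxylic acid on this aromatic carbon would read.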